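The compounds below may be only part of what the source reports. "The series", "measured", "known", "first", "only" and "open" are said of these compounds alone.

Measured compounds in a functional assay on the whole organism for inhibition, with Mythimna separata as the target, with a stated time of 5 days; a lower number here means that less compound is needed, a higher number that more compound is needed for the effect:
compound 1 `Cc1ccc(-c2nnc(COc3cnn(C(C)(C)C)c(=O)c3Cl)o2)cc1` gives 19900 nM
compound 2 `CC(C)(C)n1ncc(OCc2nnc(-c3cc(F)c(F)cc3F)o2)c(Cl)c1=O` gives 75700 nM
compound 3 `CC(C)(C)n1ncc(OCc2nnc(-c3cccs3)o2)c(Cl)c1=O` gives only a limit of the assay, > 299000 nM

Compound 3 stands at the top of the three values, as a limit rather than a number (the limit of > 299000 nM in this assay, at which 1 of the 3 values shown sits). The step of interest is phenyl in place of thiophen-2-yl on an aromatic carbon, which gives compound 4 `CC(C)(C)n1ncc(OCc2nnc(-c3ccccc3)o2)c(Cl)c1=O`, not yet measured in this assay. Two measured steps lead into compound 3 and bear on it. From the 4-methylphenyl of compound 1 the change to thiophen-2-yl gave an at least 15-fold higher number from compound 1 to compound 3 (1.17 log units; beyond the scatter); from the 2,4,5-trifluorophenyl of compound 2 it gave an at least 3.9-fold higher number from compound 2 to compound 3 (0.59 log units; beyond the scatter). Between those two six-membered carbon rings the difference was a 3.8-fold higher number from compound 1 to compound 2 (0.58 log units; beyond the scatter). Going from thiophen-2-yl back to a six-membered carbon ring is expected to reverse those steps; phenyl carries neither the methyl of compound 1 nor the fluorines of compound 2, so where it falls between them is open. The expected step is therefore a clear fall, an at least 7.4-fold lower number from compound 3 to compound 4 (0.87 log units; beyond the scatter). The estimate for compound 4 in this assay is 40000 nM, within 12000 nM to 150000 nM.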

Compound 4, half-maximal effective concentration: 12200 nM
The estimate for compound 4 lay 3.3-fold (0.52 log units) above the measured number; the range from low to high includes it.
By their numbers in this assay, from the lowest: compounds 4 and 1 (each within the scatter of the next); then compound 2. At a limit, above all of these: compound 3.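

At the aromatic carbon of the five-membered aromatic ring with 2 nitrogen and 1 oxygen, phenyl now gives a six-membered reference without substituents, and in this assay the ring itself marks the largest step seen at this position, phenyl in place of thiophen-2-yl (an at least 24-fold lower number from compound 3 to compound 4 (1.38 log units; beyond the scatter)). With that reference, the two substituted rings separate: hydrogen in place of methyl stays within the scatter (a 1.6-fold lower number from compound 1 to compound 4 (0.21 log units; within the scatter)), so the methyl of compound 1 shows no effect that can be told from noise, whereas phenyl in place of 2,4,5-trifluorophenyl gives a real step (a 6.2-fold lower number from compound 2 to compound 4 (0.79 log units; beyond the scatter)), so the cost within the six-membered rings lies with the fluorines of compound 2. The size of the first step has only a lower bound, since compound 3 is held at a limit and not a number: the limit of > 299000 nM in this assay, at which 1 of the 4 values shown sits.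

Open, as far as these compounds go, is whether a five-membered ring as such is the poor choice here, since furan-2-yl or thiazol-2-yl would separate ring size from the sulfur of thiophen-2-yl. Also open, from the compounds shown here alone, is which fluorine of compound 2 matters, which 4-fluorophenyl or 2-fluorophenyl would address, and whether a ring nitrogen, as in pyridin-2-yl, is tolerated.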